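One Added Methyl on Compound 3

The source may hold more compounds than are shown below. What is called first, only, known or untested is meant among the compounds shown, and "the series" means these compounds.

In a functional assay on the whole organism for antagonist activity, with Mus musculus as the target (a lower number here means that less compound is needed, a higher number that more compound is needed for the effect), compound 3 `CC1CCC(=O)N1CC#CCn1ccnc1` gives 0.54 mg/kg, level with compound 1 `CCc1nccn1CC#CCN1CCCC1=O` at 0.54 mg/kg. Within the data shown here, these two share the highest number of the three measured so far. Compound 2 `CC(=O)N(C)C(C)C#CCn1ccnc1C` needs a much lower dose, 0.05 mg/kg, a gap well beyond the usual scatter. Compound 4 `Cc1cncn1CC#CCN1C(=O)CCC1C` has methyl in place of hydrogen on an aromatic carbon, next to the ring atom that bears a large group. The measured compounds differ in several places at once, so none of them shows the effect of this single change. The estimated step of a 1.1-fold lower number from compound 3 to compound 4 (0.03 log units; within the scatter) stays within the scatter in this assay, with no direction clearly expected. For compound 4 the expected value is 0.5 mg/kg, with an estimated range from 0.12 mg/kg to 2 mg/kg.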

Compound 4, dose for half-maximal effect: 0.8 mg/kg
Compound 4: the middle estimate sits 1.6-fold (0.20 log units) below what was measured; the measured number falls inside the stated range.
By their numbers in this assay, from the lowest: compound 2; then compounds 1, 3 and 4 (each within the scatter of the next).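

Placing methyl on this aromatic carbon, next to the ring atom that bears a large group, gives the first single-place comparison in the series: in this assay it gives a 1.5-fold higher number from compound 3 to compound 4 (0.17 log units; within the scatter). At this position, then, one added carbon leaves the dose within the scatter, so the single methyl is tolerated here. No available data give a reason for this result. The compounds shown leave open whether a longer chain such as propyl, or a carboxylic acid, would be tolerated at this position as well.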